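The source may hold more compounds than are shown below. What is called first, only, known or untested is meant among the compounds shown, and "the series" means these compounds.

Measured so far, in a functional assay on MCF7 cells (Homo sapiens) for inhibition, read by sulforhodamine B assay, with a stated time of 48 h; a lower number here means a stronger inhibitor of growth, a higher number a weaker inhibitor of growth:

Compound 1 `CC(C)(C)NCc1c(C(=O)O)nn(-c2ccccc2)c1-c1ccc(F)cc1` gives > 680000 nM; this is a limit of the assay, not a number.
Compound 2 `CC(C)(C)NCc1c(C(=O)O)nn(-c2ccccc2)c1-c1ccc(Cl)cc1` gives > 652000 nM; again a limit.
Compound 3 `CC(C)(C)NCc1c(C(=O)O)nn(-c2ccccc2)c1-c1ccccc1` gives > 716000 nM; again a limit.

Among the measured compounds shown here, all three values sit at limits, so no step among them can be sized: a step that the two limits leave unreadable from compound 1 to compound 2, a step that the two limits leave unreadable from compound 3 to compound 2 and a step that the two limits leave unreadable from compound 1 to compound 3. The limits concerned are the limit of > 652000 nM in this assay, at which 1 of the 3 values shown sits, the limit of > 680000 nM in this assay, at which 1 of the 3 values shown sits, and (the limit of > 716000 nM in this assay, at which 1 of the 3 values shown sits).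

The change chloro in place of hydrogen on an aromatic carbon is thus measured once, and its step in this assay stays unreadable. The cores of compound 1 and compound 3 differ by fluoro in place of hydrogen on an aromatic carbon.

Compound 4 `CC(C)(C)NCc1c(C(=O)O)nn(-c2ccc(Cl)cc2)c1-c1ccc(F)cc1` carries the same change as compound 3 to compound 2, now on the core of compound 1: chloro in place of hydrogen on an aromatic carbon. The two descriptions of the place agree word for word, so the change is the same one. For this assay a step that the limit leaves unreadable from compound 1 to compound 4 is expected, resting on nothing more than the fact that compound 1 and compound 2 both sit at their limits. Compound 4 is accordingly estimated at 700000 nM, with a range from 300000 nM to 1500000 nM, and the most likely outcome is that the assay again reports only a limit.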

Compound 4, concentration for 50% growth inhibition: 270000 nM
Compound 4: the middle estimate sits 2.6-fold (0.41 log units) above what was measured; the measured number lies below the stated range.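

In this assay, chloro in place of hydrogen on the core of compound 1 gives an at least 2.5-fold lower number from compound 1 to compound 4 (0.40 log units; beyond the scatter), a step beyond the scatter whose true size may be larger, as the value of compound 1 is only a limit. Compound 2 gives > 652000 nM, which is likewise a limit of the assay, and the steps among compound 1, compound 2 and compound 3 cannot be read, leaving no size for the change on the core of compound 3 to set against the new step. The change therefore has one readable case and is not shown to carry from one core to another, and the chloro of compound 4 stands on a different aromatic ring from the chloro of compound 2.

Still open, going by these compounds, is whether bromo or methoxy in the place of this chloro would move the value further. Also open, on these data alone, is how the value would respond to a methyl ester in place of the carboxylic acid, or to a cyclohexylamine in place of the tert-butylamine.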